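Two methoxyphenyl isomers on a triazole, tested against colon cells

The compounds below may be only part of what the source reports. "The series", "measured", "known", "first", "only" and "open" are said of these compounds alone.

Compound 1 `COc1ccc(-n2nncc2CN2C(=O)C3(C(C#N)=C(N)Oc4c3c3nc5ccccc5nc3c3ccccc43)c3ccccc32)cc1` and compound 2 `COc1ccccc1-n1nncc1CN1C(=O)C2(C(C#N)=C(N)Oc3c2c2nc4ccccc4nc2c2ccccc32)c2ccccc21` share one core and differ only in the group attached to an aromatic nitrogen, as described by 2-methoxyphenyl in place of 4-methoxyphenyl on an aromatic nitrogen. Compound 3 `COc1ccc(-n2nncc2CN2C(=O)C3(C(C#N)=C(N)Oc4c(N)cc5nc6ccccc6nc5c43)c3ccccc32)cc1` carries a different core, and how that core differs from the core of compound 1 is not broken down here. Compound 4 `COc1ccccc1-n1nncc1CN1C(=O)C2(C(C#N)=C(N)Oc3c(N)cc4nc5ccccc5nc4c32)c2ccccc21` stands to compound 3 as compound 2 stands to compound 1, with the change (2-methoxyphenyl in place of 4-methoxyphenyl on an aromatic nitrogen); the two place descriptions match word for word, so it is the same change made on a second core.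

All three measured compounds were tested in a functional assay on HCT-116 cells (Homo sapiens) for antiproliferative activity, read by MTT assay, with a stated time of 48 h; a lower number here means a stronger inhibitor, a higher number a weaker inhibitor. Compound 1 gives > 50000 nM, which is a limit and not a number. Compound 2 likewise gives only the limit > 50000 nM. Compound 3 also reaches only the limit > 50000 nM. Because of the limit of > 50000 nM in this assay, at which 3 of the 3 values shown sit, the step that the two limits leave unreadable from compound 1 to compound 2 cannot be read in size: both ends sit at the same limit.

With the step from compound 1 to compound 2 unreadable and compound 3 itself at the limit, the expectation for compound 4 in this assay is a step that the limit leaves unreadable from compound 3 to compound 4, meaning no readable movement is anticipated. Compound 4 is therefore expected to show roughly 70000 nM, most likely again as a limit rather than a number, with a plausible range from 20000 nM to 250000 nM.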

Compound 4, half-maximal inhibitory concentration: > 50000 nM
Compound 4 gave a limit, no number (the forecaster's own chance of this, stated with the estimate: 85%); the middle value lies beyond the limit too.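

The step from compound 3 to compound 4, 2-methoxyphenyl in place of 4-methoxyphenyl, cannot be read in size, and neither can the same change from compound 1 to compound 2, because both ends of each pair give a limit and not a number: the limit of > 50000 nM in this assay, at which 4 of the 4 values shown sit.

The compounds shown leave open whether these two methoxyphenyl isomers differ at all in this assay, on either core.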